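A few compounds are considered here, and "the series" means these few. Any claim that something is new, unique, unknown or untested is made for them only; others in the source may bear on it.

Working notes on the series. Going by the values given here, compound 1 `Cc1cc(NC(=O)CC(=O)O)c2c(c1Oc1ccc(O)c(CC(C)C)c1)CCC2` gives in an in vitro assay on cells for displacement of a labelled ligand from thyroid hormone receptor beta (Homo sapiens), with a stated time of 48 h (on this read-out lower numbers stand for stronger inhibition and higher numbers for weaker inhibition), a value of 39.9 nM, the lowest of the two numbers so far; its nearest neighbour is compound 2, whose number is higher.

Compound 2 `Cc1cc(NC(=O)CC(=O)O)c2c(c1Oc1ccc(O)c(C(O)Cc3ccccc3)c1)CCC2` gives in this assay a value of 124 nM. Among the compounds with values here, the one measured step, a 3.1-fold higher number from compound 1 to compound 2 (0.49 log units; beyond the scatter), comes from replacing the isobutyl on the aromatic carbon by 1-hydroxy-2-phenylethyl.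

Compound 3 `Cc1cc(NC(=O)CC(=O)O)c2c(c1Oc1ccc(O)c(CCc3cccc(Cl)c3)c1)CCC2` is not yet measured. It differs from compound 1 as follows: 3-chlorobenzyl in place of isopropyl on a saturated chain carbon bound to an aromatic carbon.

Within the data shown here, only the step from compound 1 to compound 2 bears on this change, and only in part: it also replaces the isobutyl by a group carrying a phenyl ring at the same aromatic carbon, but with a hydroxyl that compound 3 lacks, and the ring in compound 3 carries chlorine. That step was modest and beyond the scatter, toward a higher number. For compound 3 a step in the same direction is therefore expected, of a size near the scatter limit or modest at most, in this assay.

The expected step is a 1.9-fold higher number from compound 1 to compound 3 (0.27 log units; within the scatter). The estimate for compound 3 is 75 nM, with a range from 25 nM to 220 nM.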

Compound 3, inhibition constant: 41 nM
For compound 3 the middle estimate is 1.8-fold (0.26 log units) above the measured one, and the stated range covers the measured number.
By their numbers in this assay, from the lowest: compounds 1 and 3 (each within the scatter of the next); then compound 2.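

At this position, on an aromatic carbon, a much larger group carrying a six-membered aromatic ring is compatible with a number at the level of the small alkyl group: 3-chlorobenzyl in place of isopropyl gives a 1.0-fold higher number from compound 1 to compound 3 (0.01 log units; within the scatter) in this assay. The aromatic ring alone therefore does not account for the higher number of compound 2 , as the change to 2-(3-chlorophenyl)ethyl, which keeps a ring at this carbon, gives a 3.0-fold lower number from compound 2 to compound 3 (0.48 log units; beyond the scatter). No measurement in hand gives a reason for either step.

That last step exchanges the hydroxyl-bearing chain and the unsubstituted phenyl ring together, so the compounds shown do not separate the share of the hydroxyl from that of the chlorine, and a plain 2-phenylethyl group would be needed to divide the two. Also open, on these data alone, is how this aromatic carbon responds to a group such as an amine or a carboxylic acid at the end of the chain, or to a chain longer than 2-(3-chlorophenyl)ethyl.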